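Aryl Switch at the Fused Core: Thiophene to Fluoropyridine

The source may report more compounds than this note shows. Statements on the series, on what has been measured and on what is new or still open speak of the compounds shown alone.

Measured compounds:
compound 1 `O=C(c1ccnc2cc(Br)ccc12)N1CCCCC1` gives > 20000 nM
compound 2 `COc1ccc2c(C(=O)Nc3cc(F)cc(F)c3)cc(=O)[nH]c2c1` gives > 20000 nM
compound 3 `O=C(Nc1cccc(F)c1)c1cc(=O)[nH]c2cc(-c3ccsc3)ccc12` gives 4300 nM

The three compounds were examined in a functional assay on KYSE-410 cells (Homo sapiens) for antiproliferative activity, read by MTT assay, with a stated time of 72 h; a lower number here means a stronger inhibitor, a higher number a weaker inhibitor. Compound 1 reaches only the limit of the assay, at > 20000 nM. Compound 2 likewise gives no number but a limit, > 20000 nM. Compound 3 is the single compound with a measured value, 4300 nM, and so it stands alone among the shown data. The other two values sit at the limit, as noted in the limit of > 20000 nM in this assay, at which 2 of the 3 values shown sit.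

Compound 4 `O=C(Nc1cccc(F)c1)c1cc(=O)[nH]c2cc(-c3cccnc3F)ccc12` is not yet measured. It differs from compound 3 in one place: 2-fluoropyridin-3-yl in place of thiophen-3-yl on an aromatic carbon. The group that enters keeps one hydrogen-bond acceptor and no donor, as the thiophen-3-yl did, but brings one six-membered aromatic ring with 1 hetero atom in place of the five-membered one.

Going by the values given here, with no measured step between related compounds to lean on, the expected step in this assay from compound 3 to compound 4 is small and may fall within the scatter, a 1.2-fold lower number from compound 3 to compound 4 (0.09 log units; within the scatter). Compound 4 is therefore estimated at 3500 nM, within 900 nM to 14000 nM.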

Compound 4, half-maximal inhibitory concentration: 11600 nM
Compound 4: middle estimate off by 3.3-fold (0.52 log units), on the low side; the range from low to high includes it.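

In this assay, going by these compounds alone, the change on this aromatic carbon gives the first step that can be read, as the earlier compounds offered no pair differing in one place: a 2.7-fold higher number from compound 3 to compound 4 (0.43 log units; beyond the scatter). The position therefore responds to which aromatic ring it carries, and 2-fluoropyridin-3-yl gives a higher number than thiophen-3-yl, even though the two groups count the same hydrogen-bond donors and acceptors. Compound 4 still gives a measured number rather than a limit, a result worth noting in so small a set: the limit of > 20000 nM in this assay, at which 2 of the 4 values shown sit.

This single step cannot separate the ring size, the ring nitrogen and the fluorine, since all three change together. The compounds shown also leave open how a plain phenyl ring, an amine such as morpholine or a carboxylic acid would read on this carbon.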